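The compounds below may be only part of what the source reports. "The series", "measured", "known", "first", "only" and "open" are said of these compounds alone.

In an ADME assay on MT4 cells (Homo sapiens) for cytotoxicity (on this read-out lower numbers stand for higher toxicity in this test and higher numbers for lower toxicity in this test), compound 1 `COc1ccc(C(=O)CSc2nc(Cc3ccc(Br)cc3)c(C)c(=O)[nH]2)cc1` gives only a limit of the assay, > 272000 nM. Compound 2 `COc1ccc(C(=O)CSc2nc(Cc3cc(C)cc(C)c3)c(C)c(=O)[nH]2)cc1` differs from compound 1 by 3,5-dimethylphenyl in place of 4-bromophenyl on a saturated chain carbon bound to an aromatic carbon. In this assay compound 2 also gives only a limit, > 308000 nM. The step that the two limits leave unreadable from compound 1 to compound 2 stays unreadable because the limit of > 272000 nM in this assay, at which 1 of the 3 values shown sits, and the limit of > 308000 nM in this assay, at which 1 of the 3 values shown sits, are both limits. Compound 3 `CCc1c(Cc2ccc(Br)cc2)nc(SCC(=O)c2ccc(OC)cc2)[nH]c1=O` carries a different core, differing from compound 1 by methyl in place of hydrogen on a saturated chain carbon bound to an aromatic carbon. In this assay compound 3 gives only a limit, > 264000 nM. The step that the two limits leave unreadable from compound 1 to compound 3 is likewise unreadable. Compound 4 `CCc1c(Cc2cc(C)cc(C)c2)nc(SCC(=O)c2ccc(OC)cc2)[nH]c1=O` differs from compound 3 by 3,5-dimethylphenyl in place of 4-bromophenyl on a saturated chain carbon bound to an aromatic carbon, the same change at the same place as from compound 1 to compound 2. Compound 4 is expected to sit at the limit again, an estimated step that the limit leaves unreadable from compound 3 to compound 4, because the limit of > 264000 nM in this assay, at which 1 of the 3 values shown sits, held the parent compound 3 at a limit. Compound 4 is therefore estimated at 300000 nM, between 150000 nM and 600000 nM.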

Compound 4, half-maximal cytotoxic concentration: >= 239000 nM
Compound 4 was reported as a limit (the forecaster's own chance of this, stated with the estimate: 85%); the middle value is on the limit's open side.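

Compound 2, compound 3 and compound 4 are all reported only as limits in this assay, and neither step to compound 4 can be read. The compounds shown leave open at what concentration any of them becomes toxic to these cells.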